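Aryloxyacetic Acid Variants at the Prostaglandin D2 Receptor 2

This account rests on a few compounds, and the source may have more. Where it says the series, first, only, none or still open, it means among the compounds named here.

Measured compounds:
compound 1 `O=C(O)COc1ccc(C(F)(F)F)cc1-c1ccc2c(c1)CCS2(=O)=O` 126 nM
compound 2 `CCC(Oc1ccc(C(F)(F)F)cc1-c1ccc(S(=O)(=O)CC)cc1C)C(=O)O` 178 nM

Of the compounds shown here, two have been measured in an assay on isolated protein for displacement of a labelled ligand from prostaglandin D2 receptor 2 (Homo sapiens), read by scintillation proximity assay; a higher number here means a weaker inhibitor, a lower number a stronger inhibitor. Compound 1 gives 126 nM. Compound 2 gives 178 nM, the higher of the two numbers, though its gap to compound 1 lies within the scatter of this assay, so the two cannot be ordered. Compound 3 `CCS(=O)(=O)c1ccc(-c2cc(C(F)(F)F)ccc2OC(C)(C)C(=O)O)c(C)c1` has not yet been measured. It differs from compound 2 in one place: 1-carboxy-1-methylethyl in place of 1-carboxypropyl on an oxygen on an aromatic ring. Within the data shown here, no step between measured compounds in this assay covers a change of this kind, so the expectation for compound 3 rests on the values of compound 2 and compound 1 alone. Compound 3 is expected to give a number in this assay close to that of compound 2, with a step of a 1.4-fold higher number from compound 2 to compound 3 (0.15 log units; within the scatter) that may not exceed the scatter. The estimate for compound 3 in this assay is 250 nM, within a range from 90 nM to 700 nM.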

Compound 3, half-maximal inhibitory concentration: 3980 nM
Compound 3: the middle estimate sits 16-fold (1.20 log units) below what was measured; the whole stated range lies below it.
By their numbers in this assay, from the lowest: compounds 1 and 2 (each within the scatter of the next); then compound 3.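

In this assay the exchange of 1-carboxypropyl for 1-carboxy-1-methylethyl on the oxygen on the aromatic ring, which keeps the same atoms joined differently, brings a 22-fold higher number from compound 2 to compound 3 (1.35 log units; beyond the scatter). Among these compounds, this is the first reading of a change at this place, and it shows that the assay's number depends strongly on how these atoms are arranged, even with the heavy-atom count and the carboxylic acid kept. Nothing available bears on why this rearrangement has so large an effect.

The compounds shown leave open how 1-carboxyethyl, with a single methyl on the carbon carrying the acid, or a longer chain such as 1-carboxybutyl, would read on the same oxygen. They also leave open whether a ring at that carbon, as in 1-carboxycyclopropyl, would follow compound 2 or compound 3.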